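The compounds below may be only part of what the source reports. "The series", "measured", "known", "first", "only" and "open" are said of these compounds alone.

Of the compounds shown here, two have so far been measured in a functional assay on MIA PaCa-2 cells (Homo sapiens) for inhibition, read by MTT assay, with a stated time of 7 days; on this read-out lower numbers stand for stronger inhibition and higher numbers for weaker inhibition. Compound 1 `CCOC(=O)[C@@H]1CCC[C@@H](S(=O)(=O)c2ccc(S(=O)(=O)N(CC)CC)cc2)C1` gives 16400 nM in this assay. Compound 2 `CCCN(CCC)S(=O)(=O)c1ccc(S(=O)(=O)N2CCC[C@@H](C(=O)OCC)C2)cc1` gives 2300 nM in this assay. Of the two, compound 2 has the lower number, and its gap to compound 1 lies beyond the usual scatter of such measurements, so compound 2 is the stronger inhibitor of the pair. The two share the same core but differ in more than one place, so no single change can be credited for the gap between them.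

Compound 3 `CCOC(=O)[C@@H]1CCCN(S(=O)(=O)c2ccc(C(=O)N(CC)CC)cc2)C1` has not been measured. It differs from compound 2 in a single place: diethylcarbamoyl in place of dipropylsulfamoyl on an aromatic carbon. For the measured compounds named here, no measured pair in this set shows this change on its own, so there is no direct guide to its effect. Because compound 2 gives 2300 nM, the expected step of a 2.6-fold higher number from compound 2 to compound 3 (0.42 log units; beyond the scatter) is a modest weakening that may still fall within the scatter. The estimate for compound 3 in this assay is 6000 nM, with a plausible range from 1500 nM to 25000 nM.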

Compound 3, half-maximal inhibitory concentration: 800 nM
For compound 3 the middle estimate is 7.5-fold (0.88 log units) above the measured one; measured number outside the range, below it.
By their numbers in this assay, from the lowest: compound 3; then compound 2; then compound 1.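

In this assay, putting diethylcarbamoyl in place of dipropylsulfamoyl on this aromatic carbon, para to a large group, gives a 2.9-fold lower number from compound 2 to compound 3 (0.46 log units; beyond the scatter), a modest gain in inhibition that lies beyond the usual scatter. For the compounds shown here, this is the first change in the set that can be read on its own, and it shows that the group at this position affects the result and that a sulfamoyl group is not needed there for inhibition at this level, since the smaller carbamoyl group does better on the shared core. Nothing shown here accounts for the direction or size of this step.

The step also combines two changes, as the sulfur-based link becomes a carbonyl link while the propyl chains become ethyl chains, so the two compounds cannot say which of these matters more. A dipropylcarbamoyl group at this position would help separate them, while a dimethylcarbamoyl group or a carboxylic acid would show how far the trend in this single step extends, if it extends at all.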